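Quinoline thiosemicarbazone anilides: antiproliferative readings

This account rests on a few compounds, and the source may have more. Where it says the series, first, only, none or still open, it means among the compounds named here.

Measured so far:
- compound 1 `COc1ccccc1NC(=S)N/N=C/c1ccc2ccccc2n1`: > 100000 nM
- compound 2 `NC(=S)N/N=C/c1cc2cccnc2s1`: > 100000 nM
- compound 3 `Cc1ccc(NC(=O)N/N=C/c2ccc3ccccc3n2)cc1`: > 100000 nM

In a functional assay on HT-29 cells (Homo sapiens) for antiproliferative activity, read by sulforhodamine B assay, with a stated time of 72 h (a lower number here means a stronger inhibitor, a higher number a weaker inhibitor), compound 1 gives > 100000 nM, which is a limit of the assay and not a number. Compound 2 likewise reaches only a limit. Compound 3 also stops at a limit. Where compound 1 stands is therefore set by the limit of > 100000 nM in this assay, at which 3 of the 3 values shown sit: every value shown sits at that same limit, so compound 1 takes no rank against compound 2 or compound 3, and no measured step between any two of them exists to draw on.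

The next compound, compound 4 `S=C(N/N=C/c1ccc2ccccc2n1)Nc1cccc(Cl)c1`, differs from compound 1 at one place: 3-chlorophenyl in place of 2-methoxyphenyl on an amide-type nitrogen. Nothing among the shown values ties an anilide substituent to a measurable reading, since all three measured compounds sit at the limit named in the limit of > 100000 nM in this assay, at which 3 of the 3 values shown sit. The expected step from compound 1 to compound 4 in this assay is a number no higher from compound 1 to compound 4 (the limit leaves the size open), that is none beyond the scatter, with the most likely outcome again a limit rather than a number. Compound 4 is accordingly estimated at 100000 nM, within a range of 20000 nM to 300000 nM.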

Compound 4, half-maximal inhibitory concentration: 48100 nM
The estimate for compound 4 lay 2.1-fold (0.32 log units) above the measured number, and the stated range covers the measured number.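

In this assay, going by these compounds alone, compound 4 gives 48100 nM, the only reading among the values shown that is a number and not a limit. Placing 3-chlorophenyl in place of 2-methoxyphenyl on an amide-type nitrogen, whose other neighbour is the thiocarbonyl carbon, gives an at least 2.0-fold lower number from compound 1 to compound 4 (0.31 log units; beyond the scatter), which shows that a change at this position alone can bring the core of compound 1 to a measurable reading. The size of this step remains open-ended, and it is a single step at a single position, so it marks this position as one that can alter the reading but establishes no trend across substituents, with most of the series still at the limit: the limit of > 100000 nM in this assay, at which 3 of the 4 values shown sit.

The compounds shown leave open whether the step follows from the chlorine, from its placement in 3-chlorophenyl, or from the departure of 2-methoxyphenyl. Also open, on these data alone, is how a phenyl ring carrying an amine or a carboxylic acid at this nitrogen would read in this assay, and whether any such group would give a number well below that of compound 4.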